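Swapping an isopropyl for chloro on the triazole-linked phenyl

The source may hold more compounds than are shown below. What is called first, only, known or untested is meant among the compounds shown, and "the series" means these compounds.

Of the compounds shown here, two sharing one urea-ether core have been measured. Compound 1 `Cc1cccc(-n2cc(COc3cccc(NC(=O)Nc4ccc(Cl)c(C(F)(F)F)c4)c3)nn2)c1` gives 7270 nM in a functional assay on HepG2 cells (Homo sapiens) for inhibition, read by MTT assay, with a stated time of 72 h (a higher number here means a weaker inhibitor, a lower number a stronger inhibitor), and compound 2 `CC(C)c1ccccc1-n1cc(COc2cccc(NC(=O)Nc3ccc(Cl)c(C(F)(F)F)c3)c2)nn1` gives 1900 nM. Going by the values given here, compound 2 thus stands lowest of the two numbers, with compound 1 the only neighbour, the single measured step being a 3.8-fold lower number from compound 1 to compound 2 (0.58 log units; beyond the scatter). Compound 3 `O=C(Nc1cccc(OCc2cn(-c3ccccc3Cl)nn2)c1)Nc1ccc(Cl)c(C(F)(F)F)c1` is not yet measured; it differs from compound 2 by chloro in place of isopropyl on an aromatic carbon, so that the change read one bond further out is 2-isopropylphenyl to 2-chlorophenyl. Among the compounds with values here, the one measured step altered both the group and its position at once, so it bears on this step only loosely; the new change keeps the position and shrinks the group. Within the data shown here, no measured pair isolates that. Compound 3 is therefore expected to stay close to compound 2, an estimated 1.8-fold higher number from compound 2 to compound 3 (0.27 log units; within the scatter), giving an expected 3500 nM with a range of 1200 nM to 10000 nM.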

Compound 3, half-maximal inhibitory concentration: 1960 nM
Beside the measured number, compound 3's estimate is 1.8-fold (0.25 log units) above it; measured number inside the range.
By their numbers in this assay, from the lowest: compounds 2 and 3 (each within the scatter of the next); then compound 1.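

In this assay, isopropyl gives way to chloro on an aromatic carbon ortho to a large group, and the result is a 1.0-fold higher number from compound 2 to compound 3 (0.01 log units; within the scatter) with no difference that can be told from the scatter, although 3 heavy atoms leave and only 1 enters. The 2-chlorophenyl group also shows a 3.7-fold lower number from compound 1 to compound 3 (0.57 log units; beyond the scatter) in a step of nearly the same size as the one seen earlier with 2-isopropylphenyl, so the lower number is not tied to isopropyl alone. Nothing available here explains this result.

Group and position still change together in both steps from compound 1, so the role of the position itself remains unsettled. Also open, going by these compounds, is how a methoxy group, an amine or a longer chain would fare at this place.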